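This account rests on a few compounds, and the source may have more. Where it says the series, first, only, none or still open, it means among the compounds named here.

In an assay on isolated protein for inhibition of Amine oxidase [flavin-containing] A (Rattus norvegicus) (on this read-out lower numbers stand for stronger inhibition and higher numbers for weaker inhibition), compound 1 `C#CCN(Cc1ccccc1)Cc1cc2ccccc2n1C` gives 10000 nM, the highest of the two numbers at hand, whereas compound 2 `CC#CCN(C)Cc1cc2cc(OC)ccc2n1C` gives 1.4 nM, a far lower number, well beyond the usual scatter. Compound 3 `Cn1c(CNCc2ccccc2)cc2ccccc21` has yet to be measured here. Compound 3 differs from compound 1 by hydrogen in place of propargyl on an amine nitrogen. Within the data shown here, no step between measured compounds shares this change, so the expectation rests on compound 1 alone and its value of 10000 nM. The expected step is a 3.0-fold higher number from compound 1 to compound 3 (0.48 log units; beyond the scatter) toward weaker inhibition. Compound 3 is estimated at 30000 nM, within 5000 nM to 200000 nM.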

Compound 3, inhibition constant: 34000 nM
Compound 3: middle estimate off by 1.1-fold (0.05 log units), on the low side, and the stated range covers the measured number.
By their numbers in this assay, from the lowest: compound 2; then compound 1; then compound 3.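

In this assay, among these compounds, replacing propargyl with hydrogen on the amine nitrogen gives a 3.4-fold higher number from compound 1 to compound 3 (0.53 log units; beyond the scatter), the first comparison in which only this position changes. On this core, propargyl therefore accounts for only a modest difference, and the compound without it stays at the weak end of the series. The data at hand give no explanation for this step. On these data alone, whether an allyl or ethyl group on that nitrogen would fall between compound 1 and compound 3 remains open. So does the size of this change on the core of compound 2.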